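This account rests on a few compounds, and the source may have more. Where it says the series, first, only, none or still open, it means among the compounds named here.

Measured so far in a functional assay on HeLa cells (Homo sapiens) for antiproliferative activity, read by MTT assay, with a stated time of 72 h; a higher number here means a weaker inhibitor, a lower number a stronger inhibitor:
- compound 1, `Cc1ccc(N2C(=O)COc3ccc(-c4cnc5ccccc5c4)cc32)cc1`: > 40000 nM
- compound 2, `O=C1COc2ccc(-c3ccc(O)cc3)cc2N1`: > 40000 nM

Compound 2, `O=C1COc2ccc(-c3ccc(O)cc3)cc2N1`, gives in this assay only a limit, > 40000 nM, not a number. Compound 1, `Cc1ccc(N2C(=O)COc3ccc(-c4cnc5ccccc5c4)cc32)cc1`, likewise gives only a limit in this assay, > 40000 nM. Both values shown in the series sit at the same limit, (the limit of > 40000 nM in this assay, at which 2 of the 2 values shown sit), so no ordering between compound 1 and compound 2 can be read from them.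

Compound 3, `COc1ccc(N2C(=O)COc3ccc(-c4ccc(O)cc4)cc32)cc1`, is not yet measured. It differs from compound 2 by 4-methoxyphenyl in place of hydrogen on an amide-type nitrogen in a ring.

Among the compounds with values here, with no measured step in this assay to compare against, and with both compounds shown sitting at the limit, no step beyond the scatter is expected in either direction, and the most likely outcome for compound 3 is again a limit. The estimate for compound 3 in this assay is therefore 40000 nM, within 12000 nM to 120000 nM. The step this implies, a number no higher from compound 2 to compound 3 (the limit leaves the size open), is expected to be nil against the limit.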

Compound 3, half-maximal inhibitory concentration: 16400 nM
Compound 3: middle estimate off by 2.4-fold (0.39 log units), on the high side, within the range that was stated.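

In this assay, 4-methoxyphenyl in place of hydrogen on the amide-type nitrogen in a ring gives an at least 2.4-fold lower number from compound 2 to compound 3 (0.38 log units; beyond the scatter). This position is therefore one where a change moves the read-out beyond the scatter, and compound 3 gives the series its first value that is a number rather than a limit. The full size of the step stays open, as compound 2 gives only a limit: the limit of > 40000 nM in this assay, at which 2 of the 3 values shown sit.

Whether the step belongs to 4-methoxyphenyl in particular remains open, since the compounds shown do not tell whether a benzyl or a plain methyl on the same nitrogen, or a phenyl carrying an amine in place of the methoxy, would do the same. Within the data shown here, compound 1 differs from compound 3 in more than one place, so no step between them can be read.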